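The compounds below may be only part of what the source reports. "The series", "measured", "known", "first", "only" and "open" are said of these compounds alone.

Measured in an ADME assay on MT4 cells (Homo sapiens) for cytotoxicity, read by MTT assay, with a stated time of 5 days; on this read-out lower numbers stand for higher toxicity in this test and higher numbers for lower toxicity in this test:
compound 1 `CCCNC(c1ccc(C#N)cc1)c1ccnc(Nc2ccc(C#N)cc2)n1` gives 34900 nM
compound 2 `N#C/C=C/c1ccc(C(NO)c2ccnc(Nc3ccc(C#N)cc3)n2)cc1` gives 161000 nM
compound 3 `N#C/C=C/c1ccc(C(NN)c2ccnc(Nc3ccc(C#N)cc3)n2)cc1` gives 186000 nM

Compound 3 holds the highest of the three numbers in this assay. Its nearest neighbour is compound 2, and the step of a 1.2-fold higher number from compound 2 to compound 3 (0.06 log units; within the scatter) lies within the scatter. Going by the values given here, the furthest is compound 1, whose value stands well beyond the scatter from that of compound 3, though the two differ in more than one place and no single step joins them.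

Compound 4 `CCCNC(c1ccc(/C=C/C#N)cc1)c1ccnc(Nc2ccc(C#N)cc2)n1` has not been measured. It differs from compound 3 by propyl in place of amino on an amine nitrogen. Among the compounds with values here, the only measured step at this amine nitrogen, a 1.2-fold higher number from compound 2 to compound 3 (0.06 log units; within the scatter), exchanged one small heteroatom group for another and produced no change beyond the scatter. The change to compound 4 is of another kind, and the propyl group is found only in compound 1, whose lower number cannot be separated from its other difference from compound 3. The expectation is therefore a modest step of a 2.7-fold lower number from compound 3 to compound 4 (0.42 log units; beyond the scatter) downward, with wide uncertainty. Compound 4 is estimated at 70000 nM in this assay, expected between 25000 nM and 190000 nM.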

Compound 4, half-maximal cytotoxic concentration: 34000 nM
Beside the measured number, compound 4's estimate is 2.1-fold (0.31 log units) above it; measured number inside the range.
By their numbers in this assay, from the lowest: compounds 4 and 1 (each within the scatter of the next); then compounds 2 and 3 (each within the scatter of the next).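

In this assay, the amine nitrogen proved sensitive to the change to propyl, which the exchange of hydroxy for amino had not revealed: the move from amino gives a 5.5-fold lower number from compound 3 to compound 4 (0.74 log units; beyond the scatter), and the move from hydroxy gives a 4.7-fold lower number from compound 2 to compound 4 (0.68 log units; beyond the scatter). With propyl held on that nitrogen, the group on the aromatic carbon made no difference beyond the scatter, with 2-cyanoethenyl in place of cyano giving a 1.0-fold lower number from compound 1 to compound 4 (0.01 log units; within the scatter), so in this pair the aromatic group does not separate the two values and the low numbers of the propyl compounds can no longer be set against that group. No measurement on hand explains the step at the amine nitrogen.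

The compounds leave open whether the step depends on chain length, as an ethyl group, a longer chain such as butyl, or a cyclopropyl ring on the nitrogen could show. They also leave open whether hydroxy and amino on that nitrogen would keep their high numbers with cyano on the aromatic carbon, and how a carboxylic acid or an amide at that aromatic carbon would read.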